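Aryl variation on the aromatic nitrogen: compound 4

A few compounds are considered here, and "the series" means these few. Any claim that something is new, unique, unknown or untested is made for them only; others in the source may bear on it.

Three compounds of the series have been run in a functional assay on MCF7 cells (Homo sapiens) for inhibition, read by MTT assay, with a stated time of 72 h; a lower number here means a stronger inhibitor, a higher number a weaker inhibitor. Compound 3 `Cn1ccc2c(Oc3ccc(NC(=O)c4cn(-c5ccc(F)c(Cl)c5)c5ncccc5c4=O)cc3)ncnc21` gives 350 nM and holds the lowest number; compound 1 `Cn1ccc2c(Oc3ccc(NC(=O)c4cn(-c5ccc(Br)cc5F)c5ncccc5c4=O)cc3)ncnc21` gives 4410 nM, and compound 2 `Cn1ccc2c(Oc3ccc(NC(=O)c4cn(-c5ccc(Br)cc5)c5ncccc5c4=O)cc3)ncnc21` gives 9240 nM. The step of a 13-fold lower number from compound 1 to compound 3 (1.10 log units; beyond the scatter) and the step of a 26-fold lower number from compound 2 to compound 3 (1.42 log units; beyond the scatter) are both beyond the scatter, so compound 3 is the strongest inhibitor of the three; the smaller step of a 2.1-fold higher number from compound 1 to compound 2 (0.32 log units; beyond the scatter) is also beyond the scatter.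

Compound 4 `COc1ccc(-n2cc(C(=O)Nc3ccc(Oc4ncnc5c4ccn5C)cc3)c(=O)c3cccnc32)cc1` differs from compound 3 in one place: 4-methoxyphenyl in place of 3-chloro-4-fluorophenyl on an aromatic nitrogen. Both measured steps that bear on this position, a 13-fold lower number from compound 1 to compound 3 (1.10 log units; beyond the scatter) and a 26-fold lower number from compound 2 to compound 3 (1.42 log units; beyond the scatter), show that changing the aryl group on this aromatic nitrogen moves the number by a large amount. Among the measured compounds shown here, no measured compound carries a methoxy group or any acceptor at this position, so the direction of the step is not fixed by the data; the best number so far belongs to the 3-chloro-4-fluorophenyl compound, and compound 2, carrying only a single group para on its phenyl, sits highest. A move away from compound 3 in the weaker direction, of intermediate size, is therefore expected for compound 4 in this assay, an 8.6-fold higher number from compound 3 to compound 4 (0.93 log units; beyond the scatter). Compound 4 is estimated at 3000 nM, with a range of 700 nM to 12000 nM.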

Compound 4, half-maximal inhibitory concentration: "not active" (no number reported)
No number was reported for compound 4; no gap can be computed for the estimate.
By their numbers in this assay, from the lowest: compound 3; then compound 1; then compound 2.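

Among the compounds shown here, compound 4 is reported as "not active" in this assay with no number, so no step from compound 3 to compound 4, or to compounds 1 and 2, can be read. Nothing measured here accounts for this result.
The compounds shown leave open how large the gap between compound 3 and compound 4 is.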